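Solubility notes: replacing the trimethylpyrazolyl group on the shared core

The source may report more compounds than this note shows. Statements on the series, on what has been measured and on what is new or still open speak of the compounds shown alone.

Measured so far in a physicochemical assay for solubility, at pH 7.4; on this read-out lower numbers stand for lower solubility and higher numbers for higher solubility:
compound 1 `Cc1cc(C)c(-c2ncc[nH]2)cc1NC(=O)c1ccc(OCc2ccccn2)cc1`: 2000 nM
compound 2 `Cc1cc(C)c(-c2c(C)nn(C)c2C)cc1NC(=O)c1ccc(OCc2ccccn2)cc1`: 35000 nM

For the measured compounds named here, compound 2 holds the higher of the two numbers; the only measured step, an 18-fold higher number from compound 1 to compound 2 (1.24 log units; beyond the scatter), separates them. Compound 3 `Cc1cc(C)c(-c2ccc(N)nn2)cc1NC(=O)c1ccc(OCc2ccccn2)cc1` differs from compound 2 by 6-aminopyridazin-3-yl in place of 1,3,5-trimethyl-1H-pyrazol-4-yl on an aromatic carbon. Going by the values given here, no measured step covers this exchange. Among the compounds with values here, the single known step, an 18-fold higher number from compound 1 to compound 2 (1.24 log units; beyond the scatter), bears on it only in so far as the group it introduced is now taken away again, though what enters is a different ring. A drop beyond the scatter in this assay is therefore expected, likely smaller than that measured step. Compound 3 is estimated at 6000 nM, with a range of 1500 nM to 25000 nM, the expected step being a 5.8-fold lower number from compound 2 to compound 3 (0.77 log units; beyond the scatter).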

Compound 3, solubility: 6000 nM
Estimate against measurement, compound 3: no gap at the digits printed; low and high end bracket the measured number.
By their numbers in this assay, from the lowest: compound 1; then compound 3; then compound 2.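

6-aminopyridazin-3-yl places a six-membered ring at this aromatic carbon, and in this assay it lands between the two five-membered rings, with a 5.8-fold lower number from compound 2 to compound 3 (0.77 log units; beyond the scatter) and a 3.0-fold higher number from compound 1 to compound 3 (0.48 log units; beyond the scatter). Ring size alone therefore does not order these three groups at this position. Nothing available accounts for this order.

Still open, from the compounds shown here alone, is how much of the change belongs to the amine on the pyridazine ring. A plain pyridazin-3-yl, or a dimethylamino group or carboxylic acid in place of that amine, would separate the ring from its substituent.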